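Replacing an Aryl Amide with a Free Acid

This account rests on a few compounds, and the source may have more. Where it says the series, first, only, none or still open, it means among the compounds named here.

Measured so far:
Compound 1 `C=C/C(C)=C/CC/C(C)=C/c1cc(C(=O)OC)co1` — 25100 nM in a functional assay on DU-145 cells (Homo sapiens) for cytotoxicity, read by MTT assay, with a stated time of 48 h; a lower number here means a stronger inhibitor, a higher number a weaker inhibitor
Compound 2 `C=C/C(C)=C\CC/C(C)=C/c1cc(C(=O)Nc2ccc(C)cc2)co1` — 56500 nM in this assay
Compound 3 `C=C/C(C)=C\CC/C(C)=C/c1cc(C(=O)N2CCN(C(c3ccccc3)c3ccccc3)CC2)co1` — 16800 nM in this assay

Among these three, compound 2 gives the highest number and so the weakest inhibition in this assay. Its nearest neighbour is compound 1, whose number is lower by a margin beyond the usual scatter, and compound 3 sits lower still, also beyond the scatter. For the measured compounds named here, no single-point step between these three can be drawn, since each pair differs in more than one place.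

Compound 4 `C=C/C(C)=C\CC/C(C)=C/c1cc(C(=O)O)co1` has not yet been measured. It differs from compound 2 in one place: hydroxy in place of (4-methylphenyl)amino on a carbonyl carbon. A single-atom group thus takes the place of a group carrying an aromatic ring.

Going by the values given here, with no measured step of this kind to lean on, the step of a 1.1-fold lower number from compound 2 to compound 4 (0.05 log units; within the scatter) is expected to be modest, and may well fall within the scatter. Compound 4 is therefore estimated at 50000 nM, with a likely range from 18000 nM to 150000 nM.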

Compound 4, half-maximal inhibitory concentration: 60100 nM
Compound 4: the middle estimate sits 1.2-fold (0.08 log units) below what was measured, within the range that was stated.
By their numbers in this assay, from the lowest: compounds 3 and 1 (each within the scatter of the next); then compounds 2 and 4 (each within the scatter of the next).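

For the compounds shown here, this is the first step that can be read at a single place: on a carbonyl carbon whose other neighbour is an aromatic carbon, hydroxy in place of (4-methylphenyl)amino gives a 1.1-fold higher number from compound 2 to compound 4 (0.03 log units; within the scatter) in this assay. A group carrying an aromatic ring can therefore give way to a single oxygen-bearing group with no difference this assay can separate from scatter, at least for this pair. Nothing available here accounts for the match between the two numbers.

A plain amino group or a methylamino group on the same carbonyl carbon could show whether other small groups also read alike here. A phenylamino group without its methyl, or one carrying a chlorine, would test whether this aromatic ring's substituent matters at all.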